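Ether for amine: the step from compound 2 to compound 3

A few compounds are considered here, and "the series" means these few. Any claim that something is new, unique, unknown or untested is made for them only; others in the source may bear on it.

Two compounds of the series carry numbers in a functional assay on cells for antagonist activity at Free fatty acid receptor 1 (Homo sapiens), read by TR-FRET and inositol phosphate accumulation, with a stated time of 2 h; a lower number here means a stronger inhibitor, a higher number a weaker inhibitor. Compound 1 `COc1ccccc1OCc1cc(C)nc(-c2ccccn2)n1` gives 2000 nM in this assay. Compound 2 `Fc1ccc(OCc2cc(N3CC4(CCO4)C3)nc(-c3ccccn3)n2)c(F)c1F` gives 501 nM in this assay, the lower of the two numbers; the gap to compound 1 lies beyond the scatter, so compound 2 is the stronger of the pair on the numbers shown. The two differ in several places at once, so no single change can be read from that gap.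

Compound 3 `COC1(COc2cc(COc3ccc(F)c(F)c3F)nc(-c3ccccn3)n2)COC1` is not yet measured. It differs from compound 2 by a group of 8 heavy atoms (5 carbon, 3 oxygen; one four-membered non-aromatic ring with 1 hetero atom) in place of a group of 7 heavy atoms (5 carbon, 1 nitrogen, 1 oxygen; 2 four-membered non-aromatic rings with 1 hetero atom each), on an aromatic carbon. Within the data shown here, no pair of measured compounds shows this change, so its effect is unknown; the only anchor is the value of compound 2. With a group of similar size taking the same place, the change is expected to move this assay by little, and the step from compound 2 to compound 3 is estimated as a 1.6-fold higher number from compound 2 to compound 3 (0.20 log units; within the scatter), toward a somewhat higher number. For compound 3 the estimate in this assay is 800 nM, with a range from 250 nM to 2500 nM.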

Compound 3, half-maximal inhibitory concentration: 501 nM
Compound 3: middle estimate off by 1.6-fold (0.20 log units), on the high side; the measured number falls inside the stated range.
By their numbers in this assay, from the lowest: compounds 2 and 3 (each within the scatter of the next); then compound 1.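

In this assay, among these compounds, (3-methoxyoxetan-3-yl)methoxy in place of the group with 2 four-membered non-aromatic rings, on this aromatic carbon of the six-membered aromatic ring, gives no change at the digits printed from compound 2 to compound 3 (within the scatter), the first reading of a single change. At this carbon, then, an attachment through oxygen can stand in for the attachment through nitrogen in compound 2 with no shift beyond the scatter, even with one four-membered ring in place of two and 3 hydrogen-bond acceptors in place of 2. No measurement is at hand that would explain why the two groups read alike, so this remains an observation on the numbers alone.

Among the compounds shown here, the single step leaves open how much of the entering group matters, for instance whether a plain methoxy group, a longer alkoxy chain or an open-chain amine at this carbon would read the same way. It also leaves open whether a carboxylic acid here would hold the number in this assay, and whether the same swap would read alike with other groups elsewhere on the shared core.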